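Series notes: aryl-to-benzyl swap on the fused core

A few compounds are considered here, and "the series" means these few. Any claim that something is new, unique, unknown or untested is made for them only; others in the source may bear on it.

Compound 1 `C=C(Br)C(=O)Nc1cccc(-c2cn3nc(-c4ccc(OC)c(OC)c4)sc3n2)c1` gives the lowest number of the three measured in a functional assay on HeLa cells (Homo sapiens) for inhibition, read by cell counting, with a stated time of 4 days (a higher number here means a weaker inhibitor, a lower number a stronger inhibitor), at 610 nM. Its nearest neighbour on the numbers is compound 3 `Nc1cccc(-c2cn3nc(Cc4ccccc4)sc3n2)c1`, which in this assay gives 24000 nM, a gap beyond the scatter. Compound 2 `COc1cccc(-c2nn3cc(-c4cccc(N)c4)nc3s2)c1` is furthest, giving 230000 nM in this assay. Compounds 2 and 3 both carry the free amine where compound 1 carries the bromoacrylamide, and of the two, compound 3 with its benzyl shows the lower number.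

Compound 4 `C=C(Br)C(=O)Nc1cccc(-c2cn3nc(Cc4ccc(Cl)cc4)sc3n2)c1` keeps the bromoacrylamide of compound 1 and differs in one place: 4-chlorobenzyl in place of 3,4-dimethoxyphenyl on an aromatic carbon. Within the data shown here, no single-point step between measured compounds covers this exchange, so the expectation rests on compound 1 alone. A small shift is expected, toward a weaker inhibitor, at or just beyond the scatter, giving a 1.6-fold higher number from compound 1 to compound 4 (0.21 log units; within the scatter). Compound 4 is therefore estimated at 1000 nM in this assay, within a range of 200 nM to 5000 nM.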

Compound 4, half-maximal inhibitory concentration: 2700 nM
Estimate against measurement, compound 4: 2.7-fold (0.43 log units) below; the measured number falls inside the stated range.
By their numbers in this assay, from the lowest: compound 1; then compound 4; then compound 3; then compound 2.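

Among these compounds, with the bromoacrylamide held fixed, the first single-place step is readable in this assay: 4-chlorobenzyl in place of 3,4-dimethoxyphenyl gives a 4.4-fold higher number from compound 1 to compound 4 (0.65 log units; beyond the scatter). This position on the five-membered aromatic ring therefore responds to the exchange, though the step is modest, and inhibition stays measurable with the benzyl group in place. The exchange alters several things at once, replacing the two methoxy groups with a chlorine and adding a carbon link to the aromatic ring, and no measurement available here accounts for the shift.

Which of these alterations carries the step remains open; a 4-chlorophenyl or a 3,4-dimethoxybenzyl group at this position would separate the link from the ring substituents. Also open, on these data alone, is whether the same exchange gives a similar step when the free amine replaces the bromoacrylamide.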